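The source may report more compounds than this note shows. Statements on the series, on what has been measured and on what is new or still open speak of the compounds shown alone.

Working notes on the series. In a functional assay on CCRF-CEM cells (Homo sapiens) for inhibition, read by MTT assay, with a stated time of 2 days, tested at 10 uM (on this read-out lower numbers stand for less inhibition and higher numbers for more inhibition at the one concentration tested (going by the name of the read-out)), compound 1 `O=C(OCCCc1ccccc1)c1cc(-n2cc(-c3cccc(O)c3)nn2)ccc1O` gives 9%. In this assay, among the compounds with values here, compound 2 `COc1cc(OC)cc(-c2cn(-c3ccc(O)c(C(=O)OCCCc4ccccc4)c3)nn2)c1` gives 8%, the lowest of the two numbers, though its nearest neighbour is compound 1 and the only measured step, a number 1 percentage points lower from compound 1 to compound 2 (within the scatter), left the read-out unchanged beyond the scatter. Compound 3 `COc1ccccc1-c1cn(-c2ccc(O)c(C(=O)OCCCc3ccccc3)c2)nn1` is not yet measured; it carries 2-methoxyphenyl in place of 3,5-dimethoxyphenyl on an aromatic carbon. Within the data shown here, the single measured step bears directly on this change, as it also exchanged the aryl group on the same aromatic carbon of the five-membered ring, and it stayed within the scatter. No step beyond the scatter is therefore expected in either direction. The step from compound 2 to compound 3 is expected to be no change at the digits printed from compound 2 to compound 3 (within the scatter). In this assay compound 3 is estimated at 8%, within a range of 0% to 20%.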

Compound 3, a percentage reported as inhibition, at one concentration (the size of the read-out at that concentration, not a potency): 4%
Compound 3: middle estimate off by 4 percentage points, on the high side; low and high end bracket the measured number.
By their numbers in this assay, from the lowest: compounds 3, 2 and 1 (each within the scatter of the next).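

Across the aryl groups on this aromatic carbon of the five-membered ring, this assay gives a number 4 percentage points lower from compound 2 to compound 3 (within the scatter) with 2-methoxyphenyl in place of 3,5-dimethoxyphenyl, and a number 5 percentage points lower from compound 1 to compound 3 (within the scatter) with 2-methoxyphenyl in place of 3-hydroxyphenyl. Within the data shown here, the position has now carried three different aryl groups, including one with its single methoxy group at a new place on the phenyl ring, and all three pairs of compounds remain within the scatter of each other, so the read-out does not separate them. No supporting data bear on why these numbers sit where they do.

Going by these compounds, all three compounds carry a substituted phenyl at this position, so the outcome with an aminomethyl group or a carboxylic acid on that phenyl, or with a pyridine in its place, remains open. The rest of the core is shared, which also leaves open what an amide in place of the ester would do.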